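The source may report more compounds than this note shows. Statements on the series, on what has been measured and on what is new or still open speak of the compounds shown alone.

Compound 1 `COc1ccc(-c2nc(C(C)(C)S(=O)(=O)c3cccc(Cl)c3)nc3ccsc23)cn1` has been tested in an ADME assay on cells (Homo sapiens) for cytotoxicity, read by resazurin assay, with a stated time of 5 days (a lower number here means that less compound is tolerated, a higher number that more compound is tolerated), where compound 1 gives > 50000 nM, a limit and not a number. Compound 3 `COc1ccc(-c2nc(COc3cccc(Cl)c3)nc3ccsc23)cn1` gives > 50000 nM, also a limit. Compound 2 `c1ccc(-c2cc(CNc3nncc(-c4cccc5ccccc45)n3)n[nH]2)cc1` gives > 10000 nM, again a limit. Compound 1 therefore has no exact value to compare with the others. Compound 4 `COc1ccc(-c2nc(C(C)S(=O)(=O)c3cccc(Cl)c3)nc3ccsc23)cn1` differs from compound 1 in one place: hydrogen in place of methyl on a saturated chain carbon bound to an aromatic carbon, a saturated chain carbon and a sulfonyl sulfur. Among the compounds with values here, no measured pair shows this change. The expected step of a number no higher from compound 1 to compound 4 (the limit leaves the size open) stays within the usual scatter of this assay, with no direction expected. For compound 4 the estimate is 50000 nM, with an expected range from 20000 nM to 100000 nM.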

Compound 4, half-maximal cytotoxic concentration: > 50000 nM
Compound 4: a limit, no number; the forecaster's own chance of this, stated with the estimate: 85%; the middle value sits exactly at the limit.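

Compound 1 and compound 4 both give only a limit in this assay, so the step between them cannot be read. None of the compounds shown gives an exact number, which leaves open whether hydrogen in place of methyl changes cytotoxicity at all.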